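The source may hold more compounds than are shown below. What is called first, only, known or untested is meant among the compounds shown, and "the series" means these compounds.

Compound 1 `COc1ccc(S(C)(=O)=O)c(NCC2=NCCN2)c1` carries a methoxy group on its aromatic ring and was tested in an assay on CHO cells for binding affinity to Alpha-2C adrenergic receptor (Homo sapiens), read by radioligand binding; on this read-out lower numbers stand for stronger inhibition and higher numbers for weaker inhibition. For compound 1 this assay reports only a limit, < 5020 nM, so its affinity is not known as a number. That situation is captured by the limit of < 5020 nM in this assay, at which 1 of the 2 values shown sits. A second compound, compound 2 `CS(=O)(=O)c1cccc(F)c1NCC1=NCCN1`, carries a fluoro group elsewhere on the same core and in this assay gives 692 nM, a number rather than a limit. Compound 3 `CS(=O)(=O)c1ccc(F)cc1NCC1=NCCN1` has not yet been measured; it differs from compound 1 by fluoro in place of methoxy on an aromatic carbon. For the measured compounds named here, no measured step between close neighbours is available to calibrate this change, so the expectation rests mainly on compound 2 and its 692 nM. The step from compound 1 to compound 3 is expected to be a step that the limit leaves unreadable from compound 1 to compound 3, toward stronger binding, though it may still fall within the usual scatter. Compound 3 is therefore estimated at 1500 nM, with a range from 300 nM to 6000 nM.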

Compound 3, inhibition constant: < 5020 nM
Compound 3 ended at the assay's limit; the forecaster's own chance of this, stated with the estimate: 25%; the middle value lies beyond the limit too.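

Compound 1 and compound 3 both end at a limit rather than a number, so no step between them can be read in this assay: the limit of < 5020 nM in this assay, at which 2 of the 3 values shown sit.

As far as these compounds go, whether fluoro in place of methoxy on an aromatic carbon changes the binding at all, and in which direction, stays open.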